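Swapping Methyl for Phenyl on a Tetrazole Side Chain

The source may hold more compounds than are shown below. What is called first, only, known or untested is meant among the compounds shown, and "the series" means these compounds.

Compound 1 `CC(CCc1ccc(OCc2ccc3ccccc3n2)cc1)Cc1nnn[nH]1` gives 25 nM in an assay on membranes from lung (Cavia porcellus) for binding affinity to cysteinyl leukotriene receptor (Homo sapiens); on this read-out lower numbers stand for stronger inhibition and higher numbers for weaker inhibition.
Compound 2 `O=C(O)CCC(Cc1ccc(OCc2ccc3ccccc3n2)cc1)c1ccccc1` gives 31 nM.
Compound 3 `CC(CCc1nnn[nH]1)Cc1ccc(OCc2ccc3ccccc3n2)cc1` gives 12 nM.

Compound 3 stands at the lowest of the three numbers, with compound 1 the nearest and compound 2 the furthest, both beyond the usual scatter. For the measured compounds named here, the only measured step, a 2.1-fold lower number from compound 1 to compound 3 (0.32 log units; beyond the scatter), concerns where the tetrazole sits on the chain and so does not test the change now in question.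

Compound 4 `c1ccc(C(CCc2nnn[nH]2)Cc2ccc(OCc3ccc4ccccc4n3)cc2)cc1` differs from compound 3 by phenyl in place of methyl on a saturated chain carbon bound to two saturated chain carbons. Going by the values given here, no measured pair isolates this swap. Among the compounds with values here, compound 2 carries a phenyl at a branch of the same kind, but it also bears a carboxylic acid where compounds 3 and 4 bear a tetrazole, so its number beside that of compound 3 shows only that a phenyl-bearing compound still lands within a modest span of the best value. On that thin basis the step from compound 3 to compound 4 is expected to be small, most likely a slight rise in the number, as a 1.7-fold higher number from compound 3 to compound 4 (0.22 log units; within the scatter). Compound 4 is therefore estimated at 20 nM in this assay, within a range from 6 nM to 65 nM.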

Compound 4, inhibition constant: 8 nM
Compound 4: the middle estimate sits 2.5-fold (0.40 log units) above what was measured; the range from low to high includes it.
By their numbers in this assay, from the lowest: compounds 4 and 3 (each within the scatter of the next); then compounds 1 and 2 (each within the scatter of the next).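

Compound 4 shows that this saturated chain carbon bound to two saturated chain carbons can carry a much larger group without a clear change in this assay: replacing methyl, with its 1 heavy atom, by phenyl, with its 6 heavy atoms and an aromatic ring, gives a 1.5-fold lower number from compound 3 to compound 4 (0.18 log units; within the scatter). Compounds 3 and 4 therefore cannot be ranked against each other, and the swap can be described only as tolerated here, not as a gain. For the compounds shown here, compound 4 also supplies a clean comparison of the two end groups on the phenyl-bearing chain, since 1H-tetrazol-5-yl in place of carboxy gives a 3.9-fold lower number from compound 2 to compound 4 (0.59 log units; beyond the scatter), a modest step and the only such pair here, so it sets no general rule. Nothing available explains either step.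

From the compounds shown here alone, whether this carbon would accept a cyclohexyl ring, a benzyl group or an amine just as readily remains open. So does whether a chlorine or a methoxy group on the new phenyl ring would shift the number beyond the scatter.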